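One Fluorine, Three Places, and a Fourth Expected

A few compounds are considered here, and "the series" means these few. Any claim that something is new, unique, unknown or untested is made for them only; others in the source may bear on it.

Compound 1 `C=C1OC(=O)C=C1Cc1ccc(NC(=O)/C=C/c2ccc(F)cc2)cc1` gives 94.1% in an assay on isolated protein for inhibition of DNA topoisomerase 1 (Homo sapiens), with a stated time of 30 min, tested at 100 uM; on this read-out higher numbers stand for more inhibition at the one concentration tested (going by the name of the read-out) and lower numbers for less inhibition.
Compound 2 `C=C1OC(=O)C=C1Cc1ccc(NC(=O)/C=C/c2ccccc2F)cc1` gives 44.6% in this assay.
Compound 3 `C=C1OC(=O)C=C1Cc1ccc(NC(=O)/C=C/c2ccccc2)cc1` gives 48.6% in this assay.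

Compound 1 stands highest of the three: compound 3 is nearest, a number 45.5 percentage points lower from compound 1 to compound 3 (beyond the scatter), and compound 2 furthest, a number 49.5 percentage points lower from compound 1 to compound 2 (beyond the scatter). Compound 2 and compound 3 differ only within the scatter, a number 4 percentage points higher from compound 2 to compound 3 (within the scatter).

Compound 4 `C=C1OC(=O)C=C1Cc1ccc(NC(=O)/C=C/c2cccc(F)c2)cc1` differs from compound 1 by 3-fluorophenyl in place of 4-fluorophenyl on a double-bonded chain carbon bound to a double-bonded chain carbon. Both steps from compound 1 bear on this change: removing the fluorine cost a number 45.5 percentage points lower from compound 1 to compound 3 (beyond the scatter), and moving it to 2-fluorophenyl cost a number 49.5 percentage points lower from compound 1 to compound 2 (beyond the scatter). A drop is therefore expected, though its size for 3-fluorophenyl is uncertain; the estimated step is a number 36.1 percentage points lower from compound 1 to compound 4 (beyond the scatter). Compound 4 is expected to give 58% in this assay, within 35% to 88%.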

Compound 4, a percentage reported as inhibition, at one concentration (the size of the read-out at that concentration, not a potency): 34.5%
For compound 4 the middle estimate is 23.5 percentage points above the measured one; the measured number lies below the stated range.
By their numbers in this assay, from the lowest: compound 4; then compounds 2 and 3 (each within the scatter of the next); then compound 1.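

The place of the fluorine on the ring decides the read-out: 3-fluorophenyl in place of 4-fluorophenyl gives a number 59.6 percentage points lower from compound 1 to compound 4 (beyond the scatter) and leaves compound 1 alone at the high end. Fluoro in place of hydrogen can also lower the number, as a number 14.1 percentage points lower from compound 3 to compound 4 (beyond the scatter) shows, and the two lower fluorophenyl compounds are separated too, with a number 10.1 percentage points lower from compound 2 to compound 4 (beyond the scatter) for this change. Nothing available explains this dependence on where the fluorine sits.

Going by these compounds, whether chloro or methoxy in place of the fluoro of 4-fluorophenyl would keep the high number stays open. So does whether that number belongs to fluoro specifically.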